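Pyridinyl for Benzyl on a Weak Piperazine Analogue

This account rests on a few compounds, and the source may have more. Where it says the series, first, only, none or still open, it means among the compounds named here.

Compound 1 `Cc1cc(Cl)ccc1NC(=O)Nc1nc(NC2CC2)cc(Sc2c[nH]c3ccccc23)n1`: in a functional assay on A549 cells (Homo sapiens) for inhibition, with a stated time of 72 h (a lower number here means a stronger inhibitor, a higher number a weaker inhibitor), compound 1 gives 31500 nM.
Compound 2 `Cc1cc(Cl)ccc1NC(=O)Nc1nc(Sc2c[nH]c3ccccc23)cc(N2CCN(Cc3ccccc3)CC2)n1`: in this assay compound 2 gives only a limit, > 50000 nM.

Of the compounds shown here, two sharing the same urea-bearing core have been measured, and both are weak. Compound 1 carries a cyclopropylamine on the core and reaches a number. Compound 2 carries a piperazine with a benzyl group instead, and its value is a limit of the assay rather than a number; it sits at the limit of > 50000 nM in this assay, at which 1 of the 2 values shown sits. Within the data shown here, no single-change step between the two measured compounds exists, so their values show only that compound 1 gives a number and compound 2 does not.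

Compound 3 `Cc1cc(Cl)ccc1NC(=O)Nc1nc(Sc2c[nH]c3ccccc23)cc(N2CCN(c3ccccn3)CC2)n1` differs from compound 2 in one place: pyridin-2-yl in place of benzyl on an amine nitrogen in a ring. On these data alone, whether this change moves the inhibition is unknown from the present data; since compound 2 already sits at the limit, a step of any size in this assay cannot be read off from it. The expected outcome for compound 3 is a value close to that limit, with an at least 1.1-fold lower number from compound 2 to compound 3 (0.04 log units; that floor lies within the scatter) as the step this estimate means. Compound 3 is therefore expected to give about 45000 nM, within a range from 15000 nM to 150000 nM.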

Compound 3, half-maximal inhibitory concentration: > 50000 nM
Compound 3: only a limit was reported; the forecaster's own chance of this, stated with the estimate: 55%; middle value at least 1.1-fold (0.04 log units) away from the limit.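

In this assay compound 3 gives > 50000 nM, which is a limit of the assay and not a number. Compound 2 also gives a limit, so the step between them cannot be read, and replacing benzyl with pyridin-2-yl on the amine nitrogen of the ring shows no measurable gain in inhibition, though a change hidden beyond the limit stays possible: the limit of > 50000 nM in this assay, at which 2 of the 3 values shown sit.

The new information lies at the aromatic carbon of the shared core, where a comparison of one change is now available: 4-(pyridin-2-yl)piperazin-1-yl in place of cyclopropylamino gives an at least 1.5-fold higher number from compound 1 to compound 3 (0.20 log units; that floor lies within the scatter), and that floor alone does not establish a real loss of inhibition.

The compounds shown leave open whether any group on the outer piperazine nitrogen, such as an acetyl group or a longer chain bearing a carboxylic acid, would bring the value down to a readable number. They also leave open how a smaller amine such as dimethylamino or a morpholine ring at the aromatic carbon would compare with cyclopropylamino.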